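The compounds below may be only part of what the source reports. "The series", "measured", "known", "first", "only" and "open" are said of these compounds alone.

Measured so far in a functional assay on SW-620 cells (Homo sapiens) for cytotoxicity, read by MTT assay, with a stated time of 72 h; on this read-out lower numbers stand for stronger inhibition and higher numbers for weaker inhibition:
- compound 1 `COc1ccc(/C=C2\CCC/C(=C\c3ccc(Br)cc3)C2=O)cc1OC`: 5200 nM
- compound 2 `COc1ccc(/C=C2\CCC/C(=C\c3cccc(O)c3)C2=O)cc1OC`: 1900 nM

Compound 2, at 1900 nM, holds the lower of the two numbers, so it is the stronger inhibitor of this pair. The next structure to consider is compound 3 `COc1ccc(/C=C2\CCC/C(=C\c3ccc(O)cc3)C2=O)cc1OC`, which has not yet been measured. It differs from compound 2 in one place: 4-hydroxyphenyl in place of 3-hydroxyphenyl on a double-bonded chain carbon bound to a double-bonded ring carbon. In words, 4-hydroxyphenyl stands in place of 3-hydroxyphenyl, on a double-bonded chain carbon bound to a double-bonded ring carbon. The two compounds have the same atoms, joined differently.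

For the measured compounds named here, only one measured step offers any guide: a 2.7-fold lower number from compound 1 to compound 2 (0.44 log units; beyond the scatter). It is modest, and it exchanged 4-bromophenyl for 3-hydroxyphenyl, which is a different change from the one at hand. Going by the values given here, no measured compound carries 4-hydroxyphenyl, so the data give no direction for this move. In this assay, no step beyond the scatter is therefore expected. The expected step is a 1.2-fold higher number from compound 2 to compound 3 (0.06 log units; within the scatter). For compound 3 the estimated value is 2200 nM, with an expected range of 800 nM to 6000 nM.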

Compound 3, half-maximal inhibitory concentration: 7700 nM
Compound 3: middle estimate off by 3.5-fold (0.54 log units), on the low side; the whole stated range lies below it.
By their numbers in this assay, from the lowest: compound 2; then compounds 1 and 3 (each within the scatter of the next).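

In this assay, where the hydroxy group sits on the phenyl ring clearly counts: 4-hydroxyphenyl in place of 3-hydroxyphenyl gives a 4.1-fold higher number from compound 2 to compound 3 (0.61 log units; beyond the scatter), even though the two groups have the same atoms and the same hydrogen-bond donor and acceptor counts. Hydroxy in place of bromo on an aromatic carbon gives a 1.5-fold higher number from compound 1 to compound 3 (0.17 log units; within the scatter), which lies within the scatter, so the earlier step, a 2.7-fold lower number from compound 1 to compound 2 (0.44 log units; beyond the scatter), cannot be credited to a hydroxy group as such and holds only for the 3-hydroxyphenyl group in compound 2. Nothing shown here explains why these two hydroxyphenyl groups part ways.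

The compounds shown leave open whether the 3-hydroxyphenyl result depends on the hydroxy group itself or would also appear with another group in its place, such as 3-aminophenyl or 3-methoxyphenyl. They also leave open how a 2-hydroxyphenyl group would compare on this double-bonded chain carbon, and whether a second hydroxy group on the same phenyl ring would lower the number further or raise it.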